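Methyl in Place of Methoxy on the Aromatic Ring

This account rests on a few compounds, and the source may have more. Where it says the series, first, only, none or still open, it means among the compounds named here.

Compound 1 `C=C1C(=O)O[C@H](C)[C@@H]1c1ccc(OC)cc1` and compound 2 `C=C1C(=O)O[C@@H](C)[C@@H]1c1ccc(OC)cc1` have the same atoms and bonds and differ only in the drawn configuration at one saturated ring carbon. In a functional assay on NALM-6 cells (Homo sapiens) for cytotoxicity, read by MTT assay, with a stated time of 48 h (a lower number here means a stronger inhibitor, a higher number a weaker inhibitor), compound 1 gives 5590 nM, and compound 2 gives 5420 nM; the step of a 1.0-fold lower number from compound 1 to compound 2 (0.01 log units; within the scatter) fits with the fact that they differ only in configuration (the fact that compounds 1 and 2 differ only in the configuration as drawn). Compound 2 has the lower of the two numbers, though the gap to compound 1 is within the scatter.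

Compound 3 `C=C1C(=O)O[C@@H](C)[C@@H]1c1ccc(C)cc1` brings a different change: methyl in place of methoxy on an aromatic carbon. For the measured compounds named here, no measured step involves this kind of change, so the measured data support no direction. The expected step is a 1.1-fold higher number from compound 2 to compound 3 (0.04 log units; within the scatter). Compound 3 is estimated at 6000 nM, within a range from 2000 nM to 18000 nM.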

Compound 3, half-maximal inhibitory concentration: 4390 nM
Estimate against measurement, compound 3: 1.4-fold (0.14 log units) above; the measured number falls inside the stated range.
By their numbers in this assay, from the lowest: compounds 3, 2 and 1 (each within the scatter of the next).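

In this assay, methyl in place of methoxy on this aromatic carbon gives a 1.2-fold lower number from compound 2 to compound 3 (0.09 log units; within the scatter). The earlier pair differed only in drawn configuration, whereas this is the first group exchange shown, and it leaves the number within the scatter. Nothing available here explains this step.

On these data alone, what an amine, a carboxylic acid or a longer chain would do at this aromatic carbon stays open. So does whether the same exchange on compound 1, with its other drawn configuration, would give a similar step.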